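A few compounds are considered here, and "the series" means these few. Any claim that something is new, unique, unknown or untested is made for them only; others in the source may bear on it.

Working notes on the series.

Compound 1 `COc1ccc(N(C)c2ncnc3c2ncn3C)cc1` carries a hydrogen on the saturated chain carbon bound to an aromatic nitrogen. In a functional assay on K562 cells (Homo sapiens) for antiproliferative activity, read by MTT assay, with a stated time of 48 h (on this read-out lower numbers stand for stronger inhibition of growth and higher numbers for weaker inhibition of growth), compound 1 reaches only a limit, > 100000 nM, and no number is known for it. Compound 2 `COc1ccc(N(C)c2ncnc3c2ncn3Cc2cc(OC)cc(OC)c2)cc1` puts 3,5-dimethoxyphenyl in that place, and in this assay compound 2 gives 42000 nM, the only number shown in the series. The remaining value, that of compound 1, is a limit. The measured step is an at least 2.3-fold lower number from compound 1 to compound 2 (0.37 log units; beyond the scatter), and it sits against (the limit of > 100000 nM in this assay, at which 1 of the 2 values shown sits), so its true size is open.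

Compound 3 `COc1cc(Cn2cnc3c(Cl)ncnc32)cc(OC)c1` differs from compound 2 in chloro in place of (4-methoxyphenyl)(methyl)amino on an aromatic carbon. The single measured step concerns the saturated chain carbon, not the aromatic carbon changed here, so no measured step bears on this change, and no direction can be read from the shown numbers. Compound 3 keeps the 3,5-dimethoxyphenyl of compound 2 but loses the (4-methoxyphenyl)(methyl)amino group, and its growth inhibition is expected to be weak, likely near or at the limit. The estimated step is a 2.1-fold higher number from compound 2 to compound 3 (0.33 log units; beyond the scatter). For compound 3 in this assay the estimate is 90000 nM, with a range of 25000 nM to 300000 nM.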

Compound 3, concentration for 50% growth inhibition: > 100000 nM
Compound 3 ended at the assay's limit (the forecaster's own chance of this, stated with the estimate: 50%); at least 1.1-fold (0.04 log units) between middle value and limit.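

Compound 3 reaches only a limit in this assay, > 100000 nM. The earlier compounds shown here spoke only to the saturated chain carbon, whereas this result shows that the aromatic carbon also matters: with the 3,5-dimethoxyphenyl kept, chloro in place of (4-methoxyphenyl)(methyl)amino gives an at least 2.3-fold higher number from compound 2 to compound 3 (0.37 log units; beyond the scatter), so the 3,5-dimethoxyphenyl alone does not keep a measurable growth inhibition. Compound 2 remains the only compound with a number, each of the two single changes from it ends at the same limit, and the true size of this step is therefore open as well: the limit of > 100000 nM in this assay, at which 2 of the 3 values shown sit.

The compounds shown do not tell whether a simple amine such as dimethylamino, or a morpholine, on this aromatic carbon would keep a number, or whether the aromatic ring of the leaving group is what counts. They also leave open what the methyl on the amine nitrogen and the methoxy on the phenyl ring each contribute, and whether a hydrogen or an ethyl on that nitrogen would move the number in either direction.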